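Trifluoromethyl for Fluoro on the Chlorophenyl Arm

The source may report more compounds than this note shows. Statements on the series, on what has been measured and on what is new or still open speak of the compounds shown alone.

Compound 3 `O=C(O)/C=C/c1ccc(/C(=C(\c2ccc(F)cc2Cl)C2CCC2)c2ccc3[nH]nc(F)c3c2)cc1` gives 2 nM in a functional assay on MCF7 cells (Homo sapiens) for cytotoxicity, read by CellTiter-Glo, with a stated time of 5 days (a lower number here means a stronger inhibitor, a higher number a weaker inhibitor), the lowest of the three numbers recorded so far. Compound 1 `CC/C(=C(/c1ccc(/C=C/C(=O)O)cc1)c1ccc2[nH]nc(F)c2c1)c1ccccc1` gives 5 nM in this assay, and compound 2 `CC/C(=C(/c1ccc(/C=C/C(=O)O)cc1)c1cc(F)c2[nH]ncc2c1)c1ccccc1` gives 7.5 nM. The gap from compound 3 to each of those two lies beyond the scatter. Going by the values given here, the only one-place step among the measured compounds is a 1.5-fold higher number from compound 1 to compound 2 (0.18 log units; within the scatter), which moves the fluorine between two positions on the shared core and leaves the number within the scatter.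

Compound 4 `O=C(O)/C=C/c1ccc(/C(=C(\c2ccc(C(F)(F)F)cc2Cl)C2CCC2)c2ccc3[nH]nc(F)c3c2)cc1` differs from compound 3 by trifluoromethyl in place of fluoro on an aromatic carbon. Among the compounds with values here, no measured step touches this aromatic ring at all; the step between compound 1 and compound 2 concerns a different ring and gives no direct reading for the change. Within the data shown here, its small size is nonetheless the only guide available. On that basis a step of a 1.3-fold higher number from compound 3 to compound 4 (0.10 log units; within the scatter) is expected, with no movement beyond the scatter anticipated in either direction. Compound 4 is therefore estimated at 2.5 nM in this assay, with a range from 0.8 nM to 8 nM that allows for the change being larger than the measured steps suggest.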

Compound 4, half-maximal inhibitory concentration: 8.2 nM
Compound 4: the middle estimate sits 3.3-fold (0.52 log units) below what was measured; measured number outside the range, above it.
By their numbers in this assay, from the lowest: compound 3; then compounds 1, 2 and 4 (each within the scatter of the next).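

Going by these compounds alone, this is the first reading on the 2-chloro-4-fluorophenyl arm. In this assay, within the data shown here, trifluoromethyl in place of fluoro, para to a large group and meta to a chloro group, brings a 4.1-fold higher number from compound 3 to compound 4 (0.61 log units; beyond the scatter) and so moves the number by more than the only earlier step, which concerned a different ring and stayed within the scatter. This aromatic carbon is therefore not indifferent to what it carries, even though the exchange, from 1 heavy atom to 4 heavy atoms, adds no hydrogen-bond donor or acceptor and no net charge; nothing at hand explains the weaker result, so only its direction and size can be stated.

A single pair cannot tell whether the step follows the heavy-atom count or belongs to trifluoromethyl itself, a question that chloro, methyl, methoxy or a bare hydrogen on this carbon would bear on. Going by these compounds, it also stands on this one background, so whether the same exchange would move the number as far on the arm of compound 1 remains open.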